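Swapping the ring on the amide of a cathepsin S inhibitor

The source may hold more compounds than are shown below. What is called first, only, known or untested is meant among the compounds shown, and "the series" means these compounds.

Of the compounds shown here, two sharing one core have been measured in an assay on isolated protein for inhibition of cathepsin S (Homo sapiens), read by fluorescence, with a stated time of 20 min; a higher number here means a weaker inhibitor, a lower number a stronger inhibitor. Compound 1 `N#CCNC(=O)[C@@H]1C[C@@H](S(=O)(=O)c2ccccc2C(F)(F)F)C[C@H]1C(=O)N1CCOCC1` gives 0.9 nM in this assay. Compound 2 `N#CC1(NC(=O)[C@@H]2C[C@@H](S(=O)(=O)c3ccccc3)C[C@H]2C(=O)N2CC3(COC3)C2)CC1` gives 3 nM in this assay, the higher of the two numbers and therefore the weaker inhibitor of the pair, with the gap to compound 1 beyond the usual scatter.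

Compound 3 `N#CC1(NC(=O)[C@@H]2C[C@@H](S(=O)(=O)c3ccccc3)C[C@H]2C(=O)N2CCC(O)CC2)CC1` has not yet been measured. It differs from compound 2 in one place: a group of 7 heavy atoms (5 carbon, 1 nitrogen, 1 oxygen; one six-membered non-aromatic ring with 1 hetero atom) in place of a group of 7 heavy atoms (5 carbon, 1 nitrogen, 1 oxygen; 2 four-membered non-aromatic rings with 1 hetero atom each), on a carbonyl carbon. Among the compounds with values here, no pair of measured compounds shows what such a change at this position does, so the expectation rests only on the value of compound 2 in this assay. The step from compound 2 to compound 3 is expected to be small, no change at the digits printed from compound 2 to compound 3 (within the scatter), within the scatter in either direction. Compound 3 is estimated at 3 nM in this assay, with a range from 1 nM to 10 nM.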

Compound 3, half-maximal inhibitory concentration: 1 nM
For compound 3 the middle estimate is 3.0-fold (0.48 log units) above the measured one; low and high end bracket the measured number.
By their numbers in this assay, from the lowest: compounds 1 and 3 (each within the scatter of the next); then compound 2.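

Within the data shown here, this is the first view of what a change at this position does: in this assay, placing 4-hydroxypiperidin-1-yl on the carbonyl carbon instead of the group with two four-membered rings gives a 3.0-fold lower number from compound 2 to compound 3 (0.48 log units; beyond the scatter), a modest step. The number of heavy atoms in the group stays the same and the rest of the molecule is unchanged, so the choice of group here does affect the reading, and of these two groups, the 4-hydroxypiperidin-1-yl gives the stronger inhibitor. No measurement at hand explains the step, so it cannot be assigned to the added hydrogen-bond donor or to the change of ring.

A plain piperidine without the hydroxyl, or one carrying an amine or a carboxylic acid in its place, would help separate these possibilities. As far as these compounds go, it also remains open whether the same swap would have a similar effect alongside the other groups of compound 1.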